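A few compounds are considered here, and "the series" means these few. Any claim that something is new, unique, unknown or untested is made for them only; others in the source may bear on it.

Measured in a functional assay on L1210 cells (Mus musculus) for antiproliferative activity; on this read-out higher numbers stand for weaker inhibition and lower numbers for stronger inhibition:

Compound 1 `COc1cc(C(=O)c2sc(-c3ccc(Cl)c(Cl)c3)cc2N)cc(OC)c1OC`: 260 nM
Compound 2 `COc1cc(C(=O)c2sc(-c3cc(OC)c(OC)c(OC)c3)cc2N)cc(OC)c1OC`: 2300 nM

Of these two compounds, compound 1 stands at the lowest number, and so the stronger inhibition; compound 2 sits at a number beyond the scatter higher, so the difference between them is real. Compound 3 `COc1cc(C(=O)c2sc(-c3ccc([N+](=O)[O-])cc3)cc2N)cc(OC)c1OC` has not yet been measured. It differs from compound 1 in one place: 4-nitrophenyl in place of 3,4-dichlorophenyl on an aromatic carbon. For the measured compounds named here, the two measured compounds show only that a group of chlorine atoms on the attached ring gives a lower number than a group of methoxy groups; nothing measured shows what a nitro group does there. The step from compound 1 to compound 3 in this assay is therefore expected to be modest and toward a higher number, and it could lie within the scatter. Compound 3 is estimated at 600 nM, in a range from 150 nM to 3000 nM, which is the step of a 2.3-fold higher number from compound 1 to compound 3 (0.36 log units; beyond the scatter).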

Compound 3, half-maximal inhibitory concentration: 100 nM
For compound 3 the middle estimate is 6.0-fold (0.78 log units) above the measured one; measured number below the stated range.
By their numbers in this assay, from the lowest: compound 3; then compound 1; then compound 2.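

In this assay, putting 4-nitrophenyl in place of 3,4-dichlorophenyl on the aromatic carbon next to the ring sulfur gives a 2.6-fold lower number from compound 1 to compound 3 (0.41 log units; beyond the scatter) as a modest step beyond the scatter. This position therefore does not depend on chlorine atoms for a low number, and a ring with a nitro group and no chlorine reaches a lower number, even though the entering group carries hydrogen-bond acceptors and the leaving group has none. Nothing measured here explains this step.

The compounds shown leave open whether the nitro group itself drives the change or whether the loss of the chlorine atoms matters more. Going by these compounds, how a plain phenyl ring would compare also stays open, as does the effect of an amine or a carboxylic acid in place of the nitro group.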